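The source may hold more compounds than are shown below. What is called first, only, known or untested is meant among the compounds shown, and "the series" means these compounds.

The compounds measured so far:

Compound 1, `O=C(NO)C(F)(F)C(F)(F)C(F)(F)C(F)(F)C(F)(F)C(F)(F)C(=O)Nc1ccc(I)cc1`: 4200 nM
Compound 2, `O=C(NO)C(F)(F)C(F)(F)C(F)(F)C(F)(F)C(F)(F)C(F)(F)C(=O)Nc1ccc(-c2cn(-c3ccccc3)nn2)cc1`: 8200 nM
Compound 3, `O=C(NO)C(F)(F)C(F)(F)C(F)(F)C(F)(F)C(F)(F)C(F)(F)C(=O)Nc1nc(-c2ccccc2)cs1`: 5400 nM

All three share the same hydroxamic acid and perfluorinated chain and differ only in the aryl group on the amide nitrogen. In an assay on isolated protein for inhibition of protein deacetylase HDAC6 (Homo sapiens), read by fluorescence (on this read-out lower numbers stand for tighter binding and higher numbers for weaker binding), compound 3 stands second highest of the three numbers, yet it sits close to both neighbours: the step of a 1.3-fold higher number from compound 1 to compound 3 (0.11 log units; within the scatter) is within the scatter, and the value of compound 2 lies near it as well.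

Compound 4 is `O=C(NO)C(F)(F)C(F)(F)C(F)(F)C(F)(F)C(F)(F)C(F)(F)C(=O)Nc1ccccc1-c1ccccc1`. It differs from compound 3 in one place: 2-phenylphenyl in place of 4-phenyl-1,3-thiazol-2-yl on an amide-type nitrogen. The two measured steps both touch this same position. The step of a 1.3-fold higher number from compound 1 to compound 3 (0.11 log units; within the scatter) exchanged one aryl group on the amide nitrogen for another without moving beyond the scatter, and the step of a 2.0-fold higher number from compound 1 to compound 2 (0.29 log units; within the scatter), which replaced a substituent on that aryl ring, stayed within the scatter too. Going by the values given here, nothing measured so far shows this position driving the numbers, so no step beyond the scatter is expected in this assay.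

Compound 4 is therefore expected at 5000 nM, within a range from 2000 nM to 13000 nM. This estimate corresponds to an expected step of a 1.1-fold lower number from compound 3 to compound 4 (0.03 log units; within the scatter).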

Compound 4, dissociation constant: 9200 nM
For compound 4 the middle estimate is 1.8-fold (0.26 log units) below the measured one; the measured number falls inside the stated range.
By their numbers in this assay, from the lowest: compounds 1, 3, 2 and 4 (each within the scatter of the next, the first and the last beyond it).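

In this assay, going by these compounds alone, the step of a 2.2-fold higher number from compound 1 to compound 4 (0.34 log units; beyond the scatter) is the first at this position to pass beyond the scatter, though only modestly, so the group on the amide-type nitrogen can have some bearing on the number. The step of a 1.7-fold higher number from compound 3 to compound 4 (0.23 log units; within the scatter) stays within the scatter, so 2-phenylphenyl in place of 4-phenyl-1,3-thiazol-2-yl, a change that removes the hydrogen-bond acceptors counted for the leaving group, does not separate these two compounds. No evidence is available that accounts for either step.

All four compounds carry the same perfluorinated chain and an aromatic group on that nitrogen. Open, then, is how a cyclohexyl group, or an aryl ring bearing an amine or a carboxylic acid, would read there, and what a longer chain would do to the number.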